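Methyl for Chloro on the Fused Ring of Compound 2

A few compounds are considered here, and "the series" means these few. Any claim that something is new, unique, unknown or untested is made for them only; others in the source may bear on it.

In a functional assay on HT-29 cells (Homo sapiens) for cytotoxicity, read by MTT assay, with a stated time of 72 h (a lower number here means a stronger inhibitor, a higher number a weaker inhibitor), compound 2 `O=C(Nc1nc2ccc(Cl)cc2s1)c1cn(-c2ccccc2)nc1-c1ccc(Cl)cc1` gives 4550 nM, the lowest of the two numbers in hand. Compound 1 `Cc1ccc2nc(NC(=O)c3cn(-c4ccccc4)nc3-c3ccc(F)cc3)sc2c1` gives 22900 nM in this assay, a higher number that lies beyond the scatter. Compound 3 `Cc1ccc2nc(NC(=O)c3cn(-c4ccccc4)nc3-c3ccc(Cl)cc3)sc2c1` is not yet measured. It differs from compound 2 in one place: methyl in place of chloro on an aromatic carbon. For the measured compounds named here, no measured pair shows this exact change, so its size is unknown; the rest of compound 2 stays unchanged. Compound 3 is expected near 9000 nM, ranging from 3000 nM to 27000 nM. The expected step of a 2.0-fold higher number from compound 2 to compound 3 (0.30 log units; within the scatter) is a modest weakening, not far beyond the scatter.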

Compound 3, half-maximal inhibitory concentration: 23700 nM
Beside the measured number, compound 3's estimate is 2.6-fold (0.42 log units) below it; the range from low to high includes it.
By their numbers in this assay, from the lowest: compound 2; then compounds 1 and 3 (each within the scatter of the next).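

Read alone for the first time in this assay, methyl in place of chloro at this position gives a 5.2-fold higher number from compound 2 to compound 3 (0.72 log units; beyond the scatter) and so lies beyond the scatter, which shows that the group here matters to the read-out. Chloro in place of fluoro on an aromatic carbon, with the 6-methyl group kept, gives a 1.0-fold higher number from compound 1 to compound 3 (0.01 log units; within the scatter) and shows no difference that can be told from the scatter. As far as these compounds go, whether an amine, a methoxy group or a nitrile at this position would match chloro remains open. Nothing in hand explains why chloro and methyl differ here.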